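Bromo in Place of Trifluoromethyl on Compound 1

This account rests on a few compounds, and the source may have more. Where it says the series, first, only, none or still open, it means among the compounds named here.

Compound 1 `Fc1ccc(/C=N/Nc2nc(-c3ccc(C(F)(F)F)cc3)cs2)cc1F` was tested in a functional assay on U-87MG ATCC cells for inhibition, with U-87 MG (Homo sapiens) as the target, read by MTT assay, with a stated time of 48 h (on this read-out lower numbers stand for stronger inhibition and higher numbers for weaker inhibition), where compound 1 gives 29900 nM. Compound 2 `COc1cc(/C=N/Nc2nc(-c3ccccc3)cs2)cc(Br)c1OC` in this assay gives 74100 nM. Of the two numbers measured, compound 1 stands lowest; its gap to compound 2 lies beyond the scatter, so compound 1 is the stronger inhibitor of this pair.

Compound 3 `Fc1ccc(/C=N/Nc2nc(-c3ccc(Br)cc3)cs2)cc1F` has not yet been measured in this assay. It differs from compound 1 in one place: bromo in place of trifluoromethyl on an aromatic carbon. The change leaves the shared core untouched and sits on an aromatic carbon of a six-membered aromatic ring of carbon only, para to a large group. Going by the values given here, no pair of measured compounds shows what this change does on its own, so the expectation rests on compound 1 and the character of the change alone. The expectation is that the step of a 1.2-fold higher number from compound 1 to compound 3 (0.07 log units; within the scatter) is small, with no direction beyond the scatter. For compound 3 the estimated value in this assay is 35000 nM, with a range from 12000 nM to 100000 nM.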

Compound 3, half-maximal inhibitory concentration: > 100000 nM
Compound 3 ended at the assay's limit; the forecaster's own chance of this, stated with the estimate: 20%; middle value at least 2.8-fold (0.45 log units) away from the limit.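

In this assay, going by these compounds alone, this is the first single change that can be read on its own: bromo in place of trifluoromethyl on an aromatic carbon gives an at least 3.3-fold higher number from compound 1 to compound 3 (0.52 log units; beyond the scatter). Compound 3 gives > 100000 nM, which is a limit of the assay and not a number, so the step has a lower bound but no known size: the limit of > 100000 nM in this assay, at which 1 of the 3 values shown sits. The place on the six-membered aromatic ring of carbon only, para to a large group, is therefore not indifferent to what it carries, since this one exchange, with the shared core untouched, moves the read-out beyond the scatter towards weaker inhibition.

The compounds shown give only this one exchange at this place, so they leave open how a chloro group, an amine or a carboxylic acid there would read in this assay. They also leave open whether the same exchange would have a similar effect on another compound, as compound 2 differs from compound 1 and compound 3 in more than one place and cannot be compared with either.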